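A few compounds are considered here, and "the series" means these few. Any claim that something is new, unique, unknown or untested is made for them only; others in the source may bear on it.

Compound 1 `CNC(=O)c1cc(Oc2ccc(NC(=O)c3cc4cccnc4n(-c4ccc(F)cc4)c3=O)cc2)ccn1` gives 160 nM in a functional assay on HT-29 cells (Homo sapiens) for antiproliferative activity, read by MTT assay, with a stated time of 72 h; on this read-out lower numbers stand for stronger inhibition and higher numbers for weaker inhibition.
Compound 2 `CCCNC(=O)c1cc(Oc2ccc(NC(=O)c3cc4cccnc4n(-c4ccccc4F)c3=O)cc2)ccn1` gives 200 nM in this assay.

Compound 2 holds the higher of the two numbers, but the gap to compound 1 lies within the usual scatter, so the two values cannot be told apart. Compound 3 `CCCNC(=O)c1cc(Oc2ccc(NC(=O)c3cc4cccnc4n(-c4ccc(F)cc4)c3=O)cc2)ccn1` is unmeasured; it differs from compound 2 by 4-fluorophenyl in place of 2-fluorophenyl on an aromatic nitrogen, the same arrangement found in compound 1. Among the measured compounds shown here, no measured pair shows this change on its own, so no step beyond the scatter is expected in either direction. The estimate for compound 3 in this assay is 170 nM, between 80 nM and 360 nM, a step of a 1.2-fold lower number from compound 2 to compound 3 (0.07 log units; within the scatter).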

Compound 3, half-maximal inhibitory concentration: 84 nM
For compound 3 the middle estimate is 2.0-fold (0.31 log units) above the measured one, within the range that was stated.
By their numbers in this assay, from the lowest: compounds 3, 1 and 2 (each within the scatter of the next, the first and the last beyond it).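

Moving the fluorine from 2-fluorophenyl to 4-fluorophenyl on the aromatic nitrogen is the first change at this position seen on its own, and in this assay it gives a 2.4-fold lower number from compound 2 to compound 3 (0.38 log units; beyond the scatter), so the place of the fluorine on this ring shows in the read-out. With 4-fluorophenyl held fixed, ethyl in place of hydrogen on the saturated chain carbon bound to the amide-type nitrogen gives a 1.9-fold lower number from compound 1 to compound 3 (0.28 log units; within the scatter), and that change cannot be told from the scatter. On these data alone, what an unsubstituted phenyl, 4-chlorophenyl or a longer chain on the amide would give remains open. Nothing given here offers a reason for the step.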